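A few compounds are considered here, and "the series" means these few. Any claim that something is new, unique, unknown or untested is made for them only; others in the source may bear on it.

Measured compounds so far:
- compound 1 `Oc1cccc(-c2cc(-c3ccncc3)nc(-c3ccccc3Cl)c2)c1`: in a functional assay on HCT-15 cells (Homo sapiens) for cytotoxicity, read by CCK-8 assay and cell counting, with a stated time of 2 days (on this read-out lower numbers stand for stronger inhibition and higher numbers for weaker inhibition), compound 1 is recorded as "not determined" (no result reported)
- compound 2 `Oc1cccc(-c2cc(-c3ccccc3)nc(-c3ccccc3Cl)c2)c1`: in this assay compound 2 gives 2930 nM
- compound 3 `Oc1cccc(-c2cc(-c3cccnc3)nc(-c3ccccc3Cl)c2)c1`: in this assay compound 3 is recorded as "not determined" (no result reported)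

Compound 3 stands without a number in this assay, and the same holds for compound 1; only compound 2 carries a value. All three share one core, differing in the group on an aromatic carbon. Compound 4 `Oc1cccc(-c2cc(-c3cccs3)nc(-c3ccccc3Cl)c2)c1` is the next member to be measured. Relative to compound 3 the change is thiophen-2-yl in place of pyridin-3-yl on an aromatic carbon. Nothing measured connects compound 3 to any other compound, so no step size can be read off. With compound 2 as the only anchor, and the entering thiophen-2-yl being, like the phenyl of compound 2, a single aromatic ring, the step from compound 3 to compound 4 in this assay is expected to be none beyond the scatter, with a wide uncertainty because compound 3 itself has no number. For compound 4 the value in this assay is estimated at 3000 nM, within 900 nM to 10000 nM.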

Compound 4, half-maximal inhibitory concentration: 2790 nM
Estimate against measurement, compound 4: 1.1-fold (0.03 log units) above, within the range that was stated.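

In this assay, among these compounds, the only readable comparison at this position, next to the ring nitrogen, is a 1.1-fold lower number from compound 2 to compound 4 (0.02 log units; within the scatter): a five-membered aromatic ring with sulfur and a six-membered all-carbon aromatic ring cannot be told apart here. Compound 1 and compound 3 carry no number, so the steps involving them cannot be read. Nothing available explains why thiophen-2-yl and phenyl read alike.

Going by these compounds, it remains open whether the pyridin-3-yl of compound 3 would read differently from the phenyl of compound 2 or the thiophen-2-yl of compound 4. On these data alone, it is also open how a non-aromatic group at this position, such as an amine, a carboxylic acid or a longer alkyl chain, would read.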